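This account rests on a few compounds, and the source may have more. Where it says the series, first, only, none or still open, it means among the compounds named here.

Measured compounds:
- compound 3 `c1ccc(-c2nc[nH]n2)c(NCC2=NCCN2)c1`: 5.01 nM in an in vitro functional assay on cells (Fibroblast) for agonist activity at Alpha-1B adrenergic receptor (Homo sapiens); a higher number here means that more compound is needed for the effect, a lower number that less compound is needed
- compound 1 `CCn1ncnc1-c1ccccc1NCC1=NCCN1`: 63.1 nM in this assay
- compound 2 `CCn1cccc1-c1ccccc1NCC1=NCCN1`: in this assay only a limit, < 100000 nM

Of the two numbers, compound 3 gives the lower; the gap to compound 1 lies beyond the scatter. The limit of compound 2 is noted as a limit of < 100000 nM in this assay, at which 1 of the 3 values shown sits, and nothing further is read from it.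

Compound 4 `Cn1ccc(-c2ccccc2NCC2=NCCN2)n1` is not yet measured. It differs from compound 3 in one place: 1-methyl-1H-pyrazol-3-yl in place of 1H-1,2,4-triazol-3-yl on an aromatic carbon

Compound 1 and compound 3 show that alkylating the five-membered ring and removing its donor costs potency, so a step upward in this assay is expected for compound 4, about a 20-fold higher number from compound 3 to compound 4 (1.30 log units; beyond the scatter). Compound 4 is estimated at 100 nM, range 20 nM to 800 nM.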

Compound 4, half-maximal effective concentration: 50.1 nM
Compound 4: the middle estimate sits 2.0-fold (0.30 log units) above what was measured, within the range that was stated.
By their numbers in this assay, from the lowest: compound 3; then compounds 4 and 1 (each within the scatter of the next).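

In this assay, among these compounds, the change from 1H-1,2,4-triazol-3-yl to 1-methyl-1H-pyrazol-3-yl on the aromatic carbon gives a 10-fold higher number from compound 3 to compound 4 (1.00 log units; beyond the scatter) and is the first single-place step. Compound 4 has no hydrogen-bond donor on this group and still gives 50.1 nM as a number, not a limit. No measured property bears on the cause of this step.

As far as these compounds go, the change alters the ring atoms and adds a methyl together, so the share of each stays open. An unmethylated 1H-pyrazol-3-yl group or an ethyl on the same ring would separate them.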